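Trifluorophenyl isomers: from compound 3 to compound 4

This account rests on a few compounds, and the source may have more. Where it says the series, first, only, none or still open, it means among the compounds named here.

Of the compounds shown here, three on one shared core have been read in an ADME assay on BJ cells (Homo sapiens) for cytotoxicity, with a stated time of 72 h; on this read-out higher numbers stand for an effect only at larger amounts of compound and lower numbers for an effect already at smaller amounts: compound 1 `C=C[C@@](C)(/C=C/c1ccc(Nc2ccc(F)c(F)c2)cc1)CCC=C(C)C`, compound 2 `C=C[C@@](C)(/C=C/c1ccc(Nc2cc(F)c(F)cc2F)cc1)CCC=C(C)C` and compound 3 `C=C[C@@](C)(/C=C/c1ccc(Nc2cc(F)c(F)c(F)c2)cc1)CCC=C(C)C`. Compound 1 gives > 36600 nM, which is a limit and not a number. Compound 2 gives > 36600 nM, also a limit. Compound 3 gives > 36600 nM, again a limit, so it has no readable place in the series.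

Compound 4 `C=C[C@@](C)(/C=C/c1ccc(Nc2c(F)cc(F)cc2F)cc1)CCC=C(C)C` is the next to be read, with this change from compound 3: 2,4,6-trifluorophenyl in place of 3,4,5-trifluorophenyl on a nitrogen on an aromatic ring. Among the measured compounds shown here, three measured steps bear on it: a step that the two limits leave unreadable from compound 1 to compound 2, a step that the two limits leave unreadable from compound 1 to compound 3 and a step that the two limits leave unreadable from compound 2 to compound 3. The last is the closest, an exchange between two trifluorophenyl groups, but none of the three has a readable size.

All that can be relied on is the limit of > 36600 nM in this assay, at which 3 of the 3 values shown sit. For the measured compounds named here, an estimated step that the limit leaves unreadable from compound 3 to compound 4 stays within the scatter, with no set direction, because the limit of > 36600 nM in this assay, at which 3 of the 3 values shown sit, holds for every compound read so far. The value expected for compound 4 is 37000 nM, with an estimated range of 20000 nM to 60000 nM.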

Compound 4, half-maximal effective concentration: > 36600 nM
Compound 4: a limit, no number; the forecaster's own chance of this, stated with the estimate: 85%; the middle value is on the limit's open side.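

In this assay compound 4 gives > 36600 nM, which is a limit and not a number, so its steps from compound 1, compound 2 and compound 3 cannot be read. Whether these fluorophenyl groups differ at all in this assay stays open, with one limit for the whole series: the limit of > 36600 nM in this assay, at which 4 of the 4 values shown sit.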